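The compounds below may be only part of what the source reports. "The series", "measured", "known", "first", "only" and "open" are said of these compounds alone.

Of the compounds shown here, three built on the shared core have been tested in a toxicity assay on MDCK cells (Canis lupus familiaris) for cytotoxicity, read by crystal violet staining, with a stated time of 48 h (on this read-out lower numbers stand for higher toxicity in this test and higher numbers for lower toxicity in this test), and each returned only a limit of the test rather than a number. Compound 1 `CCc1ccc2[nH]c(=O)c(CN(Cc3ccc(C(C)(C)C)cc3)Cc3ccc(F)c(F)c3)cc2c1` gave > 33000 nM, which is a limit. Compound 2 `CCc1ccc2[nH]c(=O)c(CN(Cc3ccc(OC(F)F)cc3)Cc3ccc(C(C)(C)C)cc3)cc2c1` gave > 5000 nM, also a limit. Compound 3 `CCc1ccc2[nH]c(=O)c(CN(Cc3ccc(C(C)(C)C)cc3)[C@@H](C)c3ccc(F)cc3)cc2c1` gave > 5000 nM, again a limit. With the limit of > 33000 nM in this assay, at which 1 of the 3 values shown sits, and the limit of > 5000 nM in this assay, at which 2 of the 3 values shown sit, as the whole of the evidence, the step that the two limits leave unreadable from compound 1 to compound 2, the step that the two limits leave unreadable from compound 1 to compound 3 and the step that the two limits leave unreadable from compound 2 to compound 3 have no readable size or direction. Compound 3 thus stands on a limit, with no number that places it relative to the other two.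

Compound 4 `CCc1ccc2[nH]c(=O)c(CN(Cc3ccc(C(C)(C)C)cc3)C(C)c3ccc(OC)cc3)cc2c1` differs from compound 3 in one place: 1-(4-methoxyphenyl)ethyl in place of 1-(4-fluorophenyl)ethyl on an amine nitrogen. The measured steps that bear on this change are the two that likewise exchange the group on the amine nitrogen, from compound 1 to compound 3 and from compound 2 to compound 3, and neither could be read. For compound 4 the estimated step that the limit leaves unreadable from compound 3 to compound 4 is therefore expected to lie within the usual scatter, in no particular direction. Compound 4 is expected to give an estimated 10000 nM in this assay, with a range from 5000 nM to 50000 nM, most probably reported once more as a limit.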

Compound 4, half-maximal cytotoxic concentration: > 5000 nM
Compound 4 was reported as a limit (the forecaster's own chance of this, stated with the estimate: 80%); the middle value does not contradict the limit.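

Compound 4 returned only a limit, as did compound 1, compound 2 and compound 3, so none of the steps from those three compounds to compound 4 can be read. The compounds shown leave open the concentration at which any of the four turns toxic in this assay, and whether exchanging the groups on the amine nitrogen alters that concentration.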